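Enone series on a shared core: notes toward compound 4

The source may hold more compounds than are shown below. What is called first, only, known or untested is meant among the compounds shown, and "the series" means these compounds.

Measured so far:
compound 1 `COc1ccc(-c2cc(/C=C/C(=O)c3ccc(OC)c(OC)c3)nc3cc(-c4ccccc4)nn23)cc1`: 8700 nM
compound 2 `COc1ccc(C(=O)/C=C/c2cc(-c3ccc(OC)c(OC)c3)n3nc(-c4ccccc4)cc3n2)cc1`: 13900 nM
compound 3 `COc1ccc(/C=C/C(=O)c2cc(-c3cc(OC)c(OC)c(OC)c3)n3nc(-c4ccccc4)cc3n2)cc1OC`: 14200 nM

In a functional assay on MDA-MB-231 cells (Homo sapiens) for antiproliferative activity, read by MTT assay, with a stated time of 24 h (a higher number here means a weaker inhibitor, a lower number a stronger inhibitor), compound 1 gives 8700 nM, compound 2 gives 13900 nM and compound 3 gives 14200 nM. Compound 2 sits within the scatter of both neighbours, so the three numbers cannot be ranked against one another. Compound 4 `COc1ccc(-c2cc(C(=O)/C=C/c3ccccc3)nc3cc(-c4ccccc4)nn23)cc1OC` is the next candidate; it differs from compound 2 by (2-phenylethenyl)carbonyl in place of 2-((4-methoxyphenyl)carbonyl)ethenyl on an aromatic carbon. Within the data shown here, no pair of measured compounds shows a step that isolates this change, so nothing in the data sets a direction for it. The step from compound 2 to compound 4 is expected to stay inside the scatter, a 1.0-fold higher number from compound 2 to compound 4 (0.00 log units; within the scatter). For compound 4 in this assay the estimate is 14000 nM, with a range from 6000 nM to 35000 nM.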

Compound 4, half-maximal inhibitory concentration: 23300 nM
Compound 4: the middle estimate sits 1.7-fold (0.22 log units) below what was measured, within the range that was stated.
By their numbers in this assay, from the lowest: compounds 1, 2, 3 and 4 (each within the scatter of the next, the first and the last beyond it).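

In this assay, among these compounds, the step at this position, a 1.7-fold higher number from compound 2 to compound 4 (0.22 log units; within the scatter), is the first one that can be read there. Exchanging 2-((4-methoxyphenyl)carbonyl)ethenyl for (2-phenylethenyl)carbonyl therefore does not separate the two compounds, even though the entering group has one hydrogen-bond acceptor fewer. No supporting data bear on this result.

The exchange alters the methoxy group and the place of the carbonyl together, so their separate contributions cannot be read. From the compounds shown here alone, whether an amine or a carboxylic acid at this position would give a step beyond the scatter remains open.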